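The source may report more compounds than this note shows. Statements on the series, on what has been measured and on what is new or still open speak of the compounds shown alone.

Of the compounds shown here, three have been measured so far in a functional assay on Urethra with Alpha-1A adrenergic receptor (Oryctolagus cuniculus) as the target; on this read-out lower numbers stand for smaller maximal responses and higher numbers for larger maximal responses. Compound 1 `CC(c1cccc(NS(C)(=O)=O)c1)c1c[nH]cn1` gives 92%. Compound 2 `CS(=O)(=O)Nc1ccc(O)c2c1CCCC2c1c[nH]cn1` gives 34%. Compound 3 `CC(C)S(=O)(=O)Nc1cccc2c1CCCC2c1c[nH]cn1` gives 74%. Of these three numbers, compound 2 stands lowest. Its nearest neighbour is compound 3, whose number lies above it by a gap beyond the usual scatter, and compound 1 sits further still above it, also beyond the scatter.

The next compound to be measured is compound 4 `COc1ccc(NS(C)(=O)=O)c2c1C(c1c[nH]cn1)CCC2`. It differs from compound 2 in one place: methyl in place of hydrogen on an oxygen on an aromatic ring. Within the data shown here, no pair among the measured compounds shows this same change, so there is no measured step of this kind to lean on. What the numbers do show is that compound 2 gives the smallest maximal response, with compound 1 at 92% and compound 3 at 74% both well above it, and that makes an upward move from the lowest position seem more likely than a further fall. A step upward, of moderate size and beyond the scatter, is therefore expected, though with wide uncertainty. For compound 4 the estimated value is 55%, within a range from 25% to 85%. This estimate means an expected step of a number 21 percentage points higher from compound 2 to compound 4 (beyond the scatter).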

Compound 4, largest response reached (reported as efficacy), in percent of the reference or control that the assay uses: 57%
Estimate against measurement, compound 4: 2 percentage points below; the measured number falls inside the stated range.
By their numbers in this assay, from the lowest: compound 2; then compound 4; then compound 3; then compound 1.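

In this assay, among these compounds, the change from hydroxy to methoxy gives a number 23 percentage points higher from compound 2 to compound 4 (beyond the scatter), the first measured step for a change at this oxygen on an aromatic ring. Among the compounds shown here, earlier, no two measured compounds differed in only one place, so no shift in response could be tied to a single change; this pair shows that a methyl in place of the hydrogen on this oxygen, just one added heavy atom, is enough to move the maximal response by more than the usual scatter. No measured information is available to explain why the response moves upward with this change.

On these data alone, whether an ethoxy group or a longer chain on this oxygen would raise the response further or lower it again stays open, as does the effect of an amine in place of the hydroxy. As far as these compounds go, the step also rests on a single pair of compounds, so it remains unknown whether the same change would move the response in the same direction on a different core.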